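Swapping the aryl group on the cyclopentane: methoxy to nitro

A few compounds are considered here, and "the series" means these few. Any claim that something is new, unique, unknown or untested is made for them only; others in the source may bear on it.

The compounds here share one core: a urea linking a 2,6-diisopropylphenyl group to a methylene on a cyclopentane that also carries an aryl ring. Compound 1 `CC(C)c1ccc(C2(CNC(=O)Nc3c(C(C)C)cccc3C(C)C)CCCC2)cc1` carries a 4-isopropylphenyl ring and in an assay on microsomes for inhibition of acyl-CoA:cholesterol acyltransferase (Oryctolagus cuniculus) (on this read-out higher numbers stand for weaker inhibition and lower numbers for stronger inhibition), compound 1 gives 48 nM. Compound 2 `COc1ccc(C2(CNC(=O)Nc3c(C(C)C)cccc3C(C)C)CCCC2)cc1` carries a 4-methoxyphenyl ring and in this assay compound 2 gives 31 nM. For the measured compounds named here, compound 2 thus shows the lowest of the two numbers measured so far, but the only step available, a 1.5-fold lower number from compound 1 to compound 2 (0.19 log units; within the scatter), is within the scatter, so the two compounds cannot be told apart on these data.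

Compound 3 `CC(C)c1cccc(C(C)C)c1NC(=O)NCC1(c2cccc([N+](=O)[O-])c2)CCCC1` is not yet measured. It differs from compound 2 by 3-nitrophenyl in place of 4-methoxyphenyl on a saturated ring carbon. Going by the values given here, the one measured step concerns a change of substituent on the same aryl ring and was within the scatter; it is the only guide, and it gives no reason to expect a large shift in this assay in either direction. Compound 3 is therefore estimated at 50 nM, between 15 nM and 160 nM, which means an expected step of a 1.6-fold higher number from compound 2 to compound 3 (0.21 log units; within the scatter).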

Compound 3, half-maximal inhibitory concentration: 51 nM
Estimate against measurement, compound 3: 1.0-fold (0.01 log units) below; the measured number falls inside the stated range.
By their numbers in this assay, from the lowest: compounds 2, 1 and 3 (each within the scatter of the next).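

Placing 3-nitrophenyl on the saturated ring carbon in place of 4-methoxyphenyl gives a 1.6-fold higher number from compound 2 to compound 3 (0.22 log units; within the scatter), and placing it there in place of 4-isopropylphenyl gives a 1.1-fold higher number from compound 1 to compound 3 (0.03 log units; within the scatter). In this assay, compound 1, compound 2 and compound 3 therefore cannot be told apart, and this now holds for a nitro-bearing aryl group whose name carries a 3, whereas the two earlier aryl groups both carry a 4 in their names. Within these three compounds, then, a different substituent and a different numbered ring position arrive together in one step without moving the result outside the scatter, although no measurement given here accounts for this.

Because the substituent and its numbered position change together, these compounds do not show what each contributes alone, and a comparison of 3-nitrophenyl with 4-nitrophenyl would separate the two. On these data alone, it also remains open whether this position would keep the same range of numbers with an aryl ring carrying an amine or a carboxylic acid, or with an unsubstituted phenyl ring.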